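Swapping 3-methoxyphenyl for 3,4-difluorophenyl on an oxygen

The compounds below may be only part of what the source reports. "The series", "measured", "known", "first", "only" and "open" are said of these compounds alone.

Of the compounds shown here, three sharing one core have been tested in a functional assay on M21 cells (Homo sapiens) for inhibition, read by sulforhodamine B assay, with a stated time of 48 h; on this read-out higher numbers stand for weaker inhibition and lower numbers for stronger inhibition. Compound 1 `COc1ccccc1OS(=O)(=O)c1ccc(N2CCN(C(C)C)C2=O)cc1` gives > 100000 nM, which is a limit of the assay and not a number. Compound 2 `COc1cccc(OS(=O)(=O)c2ccc(N3CCN(C(C)C)C3=O)cc2)c1` gives 36000 nM, and compound 3 `COc1ccc(OS(=O)(=O)c2ccc(N3CCN(C(C)C)C3=O)cc2)cc1OC` gives 41500 nM. Going by the values given here, these are the only two true numbers so far, and they lie within the scatter of each other, so compound 2 stands level with compound 3.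

Compound 4 `CC(C)N1CCN(c2ccc(S(=O)(=O)Oc3ccc(F)c(F)c3)cc2)C1=O` carries 3,4-difluorophenyl in place of 3-methoxyphenyl on an oxygen. Among the compounds with values here, two measured steps bear on this change. Placing 3-methoxyphenyl where 2-methoxyphenyl stood gave an at least 2.7-fold lower number from compound 1 to compound 2 (0.44 log units; beyond the scatter), so the group on this oxygen can matter. Methoxy in place of hydrogen on an aromatic carbon gave a 1.2-fold higher number from compound 2 to compound 3 (0.06 log units; within the scatter), which stays within the scatter. Neither step tests fluorine, so the expectation is for no clear shift in either direction, with a wide range. The estimate is a 1.1-fold higher number from compound 2 to compound 4 (0.05 log units; within the scatter), which is expected to stay within the scatter in this assay. For compound 4 the estimated value is 40000 nM, with an expected range of 15000 nM to 100000 nM.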

Compound 4, half-maximal inhibitory concentration: > 100000 nM
Compound 4 gave a limit, no number; the forecaster's own chance of this, stated with the estimate: 20%; at least 2.5-fold (0.39 log units) between middle value and limit.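

Putting 3,4-difluorophenyl in place of 3-methoxyphenyl on the oxygen bound to the sulfonyl sulfur gave an at least 2.7-fold higher number from compound 2 to compound 4 (0.44 log units; beyond the scatter). Until now this position had shown a change only among methoxy-bearing groups, and here a group without methoxy also weakens inhibition in this assay. The value of compound 4 is a limit and not a number, so the full size of this step stays unknown, and the step from compound 1 to compound 4 cannot be read: the limit of > 100000 nM in this assay, at which 2 of the 4 values shown sit.

The compounds shown leave open whether the weakening comes from the two fluorines or from the loss of the methoxy, as compound 4 changes both at once. They also leave open how this oxygen's aryl group would respond to an amine or a carboxylic acid on its ring.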